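The source may hold more compounds than are shown below. What is called first, only, known or untested is meant among the compounds shown, and "the series" means these compounds.

Measured compounds and values:
Compound 1 `O=C1O[C@@H](CN2CCC(c3ccc(F)cc3)CC2)CN1c1ccc(-n2cc(-c3ccccn3)cn2)c(F)c1` in an ADME assay on L02 cells (Homo sapiens) for cytotoxicity, read by MTT assay, with a stated time of 48 h (a lower number here means a stronger inhibitor, a higher number a weaker inhibitor), gives > 400 ug/mL, which is a limit of the assay and not a number.
Compound 2 `CC(=O)OC[C@H]1CN(c2ccc(-n3cc(-c4ccccn4)cn3)c(F)c2)C(=O)O1` gives > 400 ug/mL, again only a limit.
Compound 3 `O=C(OC[C@H]1CN(c2ccc(-n3cc(-c4ccccn4)cn3)c(F)c2)C(=O)O1)c1ccccc1` gives > 400 ug/mL, also a limit.

Compound 2 therefore stands nowhere definite on the numbers shown: its own value is only a limit, and the two further values shown are limits as well. The step from compound 2 to compound 4 `CN(C)S(=O)(=O)NC[C@H]1CN(c2ccc(-n3cc(-c4ccccn4)cn3)c(F)c2)C(=O)O1` alters the group on a saturated chain carbon bound to a saturated ring carbon: (dimethylsulfamoyl)amino in place of acetoxy on a saturated chain carbon bound to a saturated ring carbon. Among the measured compounds shown here, the one measured step at the same place, a step that the two limits leave unreadable from compound 2 to compound 3, cannot be read, because the limit of > 400 ug/mL in this assay, at which 3 of the 3 values shown sit, sits at both of its ends. No direction or size of change can thus be drawn from the measured steps, and none beyond the scatter is expected here; the step that the limit leaves unreadable from compound 2 to compound 4 is estimated to remain unreadable in the same way. Compound 4 is expected to give about 500 ug/mL, in the range 200 ug/mL to 1500 ug/mL, and most probably to be reported only as a limit once more.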

Compound 4, half-maximal inhibitory concentration: 158 ug/mL
Compound 4: the middle estimate sits 3.2-fold (0.50 log units) above what was measured; the measured number lies below the stated range.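

In this assay, placing (dimethylsulfamoyl)amino on a saturated chain carbon bound to a saturated ring carbon gives an at least 2.5-fold lower number from compound 2 to compound 4 (0.40 log units; beyond the scatter), and the same group in place of benzoyloxy gives an at least 2.5-fold lower number from compound 3 to compound 4 (0.40 log units; beyond the scatter). This position can therefore move the read-out away from the limit, with the change running towards stronger inhibition of L02 cells, which the acetoxy and benzoyloxy compounds could not show. The step between those two earlier compounds still cannot be read because both sit at the same limit: the limit of > 400 ug/mL in this assay, at which 3 of the 4 values shown sit.

As far as these compounds go, the true size of both new steps stays open, as each starts from a limit, and a single compound does not separate the contribution of the sulfamoyl part from that of the amino link. A plain amine or a methanesulfonylamino group at this place would bear on that question.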